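Series notes: estimate for compound 4

This account rests on a few compounds, and the source may have more. Where it says the series, first, only, none or still open, it means among the compounds named here.

Measured so far:
compound 1 `O=S(=O)(Nc1ccc(F)c(C#Cc2cnc3[nH]ncc3c2)c1F)c1ccccc1`, 2100 nM
compound 2 `O=S(=O)(Nc1ccc(F)c(C#Cc2cnc3[nH]ncc3c2)c1F)c1ccccn1`, 2670 nM
compound 3 `COc1n[nH]c2ncc(C#Cc3c(F)ccc(NS(=O)(=O)c4cccnc4)c3F)cc12`, 89 nM

In a functional assay on COLO 205 cells (Homo sapiens) for antiproliferative activity, read by MTT assay, with a stated time of 68 h (a lower number here means a stronger inhibitor, a higher number a weaker inhibitor), compound 3 gives the lowest number of the three, with compound 1 the nearest and compound 2 the furthest, both beyond the scatter. Compound 4 is `O=S(=O)(Nc1ccc(F)c(C#Cc2cnc3[nH]nc(-c4ccccc4)c3c2)c1F)c1cccnc1`; relative to compound 3 the change is phenyl in place of methoxy on an aromatic carbon. Within the data shown here, only one measured step exists, a 1.3-fold higher number from compound 1 to compound 2 (0.10 log units; within the scatter), and it concerns the sulfonyl substituent rather than the position now altered, so it gives no direct guide. Among the measured compounds shown here, compounds 1 and 2 carry no group at that carbon and both sit far above compound 3, but no pair shows phenyl there. The step is therefore uncertain; a moderate loss is estimated, a 4.5-fold higher number from compound 3 to compound 4 (0.65 log units; beyond the scatter). Compound 4 is estimated at 400 nM, within 60 nM to 3000 nM.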

Compound 4, half-maximal inhibitory concentration: 200 nM
The estimate for compound 4 lay 2.0-fold (0.30 log units) above the measured number; measured number inside the range.
By their numbers in this assay, from the lowest: compound 3; then compound 4; then compounds 1 and 2 (each within the scatter of the next).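

In this assay, phenyl in place of methoxy gives a 2.2-fold higher number from compound 3 to compound 4 (0.35 log units; beyond the scatter), a modest loss but beyond the scatter. Among these compounds, this is the first single-place reading at this aromatic carbon, and it shows that the position still carries a six-membered aromatic ring of carbon only at a modest cost in this assay. Nothing measured accounts for the size of this step.

The compounds shown leave open what methoxy or phenyl is worth against hydrogen at this carbon with the sulfonyl substituent of compound 3 held fixed. On these data alone, how an amine or a carboxylic acid would read at this carbon also remains open.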